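The source may report more compounds than this note shows. Statements on the series, on what has been measured and on what is new or still open speak of the compounds shown alone.

Measured in an in vitro ADME assay on microsomes (Homo sapiens) for metabolic stability (a lower number here means that the compound disappears faster, a higher number that the compound lasts longer), as follows:
- compound 1 `CCc1nc(NC(CC)CC)c(Cl)nc1-c1ccc(Cl)cc1Cl` gives 0.167 h
- compound 2 `CCc1nc(-c2ccc(OC(F)(F)F)cc2OC)c(CC)nc1NC(CC)CC` gives 0.217 h
- compound 3 `CCc1nc(-c2ccc(Cl)cc2Cl)c(CC)nc1NC(COC)COC` gives 0.15 h

Compound 3 at 0.15 h lies within the scatter of both compound 1 and compound 2, so the three half-lives show no order among themselves.

The next compound to be read is compound 4 `CCc1nc(-c2ccc(Cl)cc2Cl)c(CC)nc1NC(C)CN(C)C` and it differs from compound 3 as follows: 1-((dimethylamino)methyl)ethyl in place of 2-methoxy-1-(methoxymethyl)ethyl on a nitrogen on an aromatic ring with 1-((dimethylamino)methyl)ethyl in place of 2-methoxy-1-(methoxymethyl)ethyl on a nitrogen on an aromatic ring.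

Among the compounds with values here, no pair measured so far differs in one place only, so the series offers no direct precedent for this change. The expectation rests only on the close grouping of the three values, with compound 2 at 0.217 h as the other end of that group. No change beyond the scatter is expected: the estimated 1.4-fold higher number from compound 3 to compound 4 (0.15 log units; within the scatter) is small and leans towards a longer half-life, with little confidence in that direction. Compound 4 is estimated at 0.21 h within an expected range of 0.1 h to 0.45 h on the half-life read-out.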

Compound 4, half-life: 0.117 h
For compound 4 the middle estimate is 1.8-fold (0.25 log units) above the measured one; the measured number falls inside the stated range.
By their numbers in this assay, from the lowest: compounds 4, 3, 1 and 2 (each within the scatter of the next).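

Within the data shown here, at the nitrogen on an aromatic ring, 1-((dimethylamino)methyl)ethyl in place of 2-methoxy-1-(methoxymethyl)ethyl provides the first one-place comparison, and in this assay it reads as a 1.3-fold lower number from compound 3 to compound 4 (0.11 log units; within the scatter) on an otherwise shared core. For this one pair, a chain carrying a dimethylamino group and a chain carrying two methoxy groups are not separated by half-life, so this exchange at this position does not alter the read-out beyond the scatter. Nothing available bears on why the two chains read alike.

On these data alone, whether any substituent on this nitrogen can move the half-life beyond the scatter remains open, for example a chain ending in a carboxylic acid or a cyclopropylmethyl group. As far as these compounds go, whether the same exchange reads alike on a core with a different aryl group also remains open.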